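This account rests on a few compounds, and the source may have more. Where it says the series, first, only, none or still open, it means among the compounds named here.

In an ADME assay on Vero cells (Chlorocebus sabaeus) for cytotoxicity, read by MTT assay, tested at 25 uM (on this read-out lower numbers stand for a stronger effect and higher numbers for a weaker effect at the one concentration tested), three compounds have been measured: compound 1 `CSc1ccc(C(=O)/C(=C/c2cc3ccccc3s2)c2ccc(Cl)c(Cl)c2)cc1` gives 93.4%, compound 2 `CCOC(=O)C(C(=O)c1ccc(OC)cc1)C(NC(C)=O)c1ccc(C(C)(C)C)cc1` gives 94.5%, and compound 3 `CCOC(=O)C(C(=O)c1ccc(OC)cc1)C(NC(C)=O)c1cccc2ccccc12` gives 99.2%. Compound 3 holds the highest of the three numbers, yet its gaps to compound 2 and to compound 1 both lie within the scatter, so no order can be read among them. Compound 4 `CCOC(=O)C(C(=O)c1ccc(OC)cc1)C(NC(C)=O)c1ccc(OC)c(OC)c1` differs from compound 3 by 3,4-dimethoxyphenyl in place of naphthalen-1-yl on a saturated chain carbon bound to an amide-type nitrogen and a saturated chain carbon. Among the compounds with values here, the only measured step at this place, a number 4.7 percentage points higher from compound 2 to compound 3 (within the scatter), stayed within the scatter, and no measured step brings in the entering group. Compound 4 is therefore expected to show a step of a number 3.2 percentage points lower from compound 3 to compound 4 (within the scatter), meaning none beyond the scatter. The estimate for compound 4 is 96%, with a range from 87% to 103%.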

Compound 4, a percentage reported as activity, at one concentration (the size of the read-out at that concentration, not a potency): 99.1%
Beside the measured number, compound 4's estimate is 3.1 percentage points below it, and the stated range covers the measured number.
By their numbers in this assay, from the lowest: compounds 1, 2, 4 and 3 (each within the scatter of the next).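

In this assay the step from a ring system of carbon only to one carrying two methoxy groups gave a number 0.1 percentage points lower from compound 3 to compound 4 (within the scatter) and the change from 4-(tert-butyl)phenyl gave a number 4.6 percentage points higher from compound 2 to compound 4 (within the scatter) at the same place. On this saturated chain carbon, then, the oxygen atoms and hydrogen-bond acceptors of 3,4-dimethoxyphenyl brought no readable change from either group it replaced. No supporting evidence bears on this result.

From the compounds shown here alone, only aromatic groups appear at this place, so the outcome with an amine, a carboxylic acid or a longer chain there remains open.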